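The source may report more compounds than this note shows. Statements on the series, on what has been measured and on what is new or still open speak of the compounds shown alone.

Compound 1 `O=C(O)Cc1sc(C(c2ccc(F)cc2)c2ccc(F)cc2)nc1-c1ccccc1` carries two fluorine-bearing phenyl rings on the carbon that joins them to the shared core, with an unsubstituted phenyl on the core itself. In an in vitro assay on HEK385-7 cells for displacement of a labelled ligand from prostaglandin D2 receptor 2 (Homo sapiens) (on this read-out lower numbers stand for stronger inhibition and higher numbers for weaker inhibition), compound 1 gives 16 nM. Two relatives put fluorine elsewhere: compound 2 `O=C(O)Cc1sc(C(c2ccccc2)c2ccccc2)nc1-c1ccc(F)cc1` gives 8.7 nM, and compound 3 `O=C(O)Cc1sc(C(c2ccccc2)c2ccccc2)nc1-c1ccc(F)c(F)c1` gives 4.1 nM. Compound 1 and compound 2 lie within the usual scatter of each other, so nothing separates them; compound 3 gives a number that is lower than that of compound 1 beyond the scatter. The one step that is resolved among these three, a 2.1-fold lower number from compound 2 to compound 3 (0.33 log units; beyond the scatter), concerns fluoro in place of hydrogen on an aromatic carbon.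

Compound 4 `O=C(O)Cc1sc(C(c2ccc(F)cc2)c2ccc(F)cc2)nc1-c1ccncc1` differs from compound 1 in one place: pyridin-4-yl in place of phenyl on an aromatic carbon. Going by the values given here, no measured pair shows what pyridin-4-yl in place of phenyl does on this core; the step from compound 2 to compound 3 is about fluorine on a phenyl ring, not about exchanging the ring itself, so it bears only indirectly. Among the compounds with values here, with no direct precedent, the safest expectation is a change that stays within the scatter. Compound 4 is therefore estimated at 16 nM, with a range from 6 nM to 45 nM. That estimate means a step of no change at the digits printed from compound 1 to compound 4 (within the scatter) expected to remain within the scatter.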

Compound 4, half-maximal inhibitory concentration: 5.3 nM
For compound 4 the middle estimate is 3.0-fold (0.48 log units) above the measured one, and the stated range ends above it.
By their numbers in this assay, from the lowest: compounds 3, 4, 2 and 1 (each within the scatter of the next, the first and the last beyond it).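

In this assay, exchanging the whole ring on this aromatic carbon, next to the ring nitrogen, gives a 3.0-fold lower number from compound 1 to compound 4 (0.48 log units; beyond the scatter), a step beyond the scatter. Going by these compounds alone, until now the only resolved change on this ring was the addition of a fluoro group to a phenyl that stayed in place; this step shows that replacing the phenyl itself with pyridin-4-yl also lowers the number, and so points to stronger inhibition. The two rings have the same number of heavy atoms and differ in one ring carbon exchanged for nitrogen, which adds a hydrogen-bond acceptor, but nothing available here explains why the number falls.

The compounds shown leave open whether the location of the ring nitrogen matters, which pyridin-3-yl or pyridin-2-yl at the same position could test, and whether a second ring nitrogen, as in pyrimidin-5-yl, would change the result. They also leave open whether pyridin-4-yl has the same effect on the core of compound 2, where the two phenyl rings on the joining carbon carry no fluorine.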